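The compounds below may be only part of what the source reports. "The series", "measured", "known", "first", "only" and "open" are said of these compounds alone.

Measured so far in an assay on CHO cells for agonist activity at 5-hydroxytryptamine receptor 1D (Homo sapiens), read by GTPgammaS binding; on this read-out lower numbers stand for an effect already at smaller amounts and higher numbers for an effect only at larger amounts of compound:
compound 1, `O=S(=O)(NCC1CCN(CCCc2c[nH]c3ccc(-n4cnnc4)cc23)CC1)c1ccccc1`, gives 12 nM;
compound 2, `c1ccc(CNCC2CCN(CCCc3c[nH]c4ccc(-n5cnnc5)cc34)CC2)cc1`, gives 5.6 nM;
compound 3, `OC[C@H](NC1CCN(CCCc2c[nH]c3ccc(-n4ccnc4)cc23)CC1)c1ccccc1`, gives 0.8 nM.

Compound 2 stands second highest of the three numbers in this assay. Its nearest neighbour is compound 1, and the one step that is recorded among these compounds runs between them: a 2.1-fold lower number from compound 1 to compound 2 (0.33 log units; beyond the scatter), a modest shift that lies beyond the scatter. For the measured compounds named here, compound 3 lies furthest from compound 2, at a clearly lower number, but compound 3 differs from compound 2 in more than one place, so no single step is recorded for that pair.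

Compound 4, `CN(Cc1cccs1)C1CCN(CCCc2c[nH]c3ccc(-n4cnnc4)cc23)CC1`, has not yet been measured. It differs from compound 2 by methyl((thiophen-2-yl)methyl)amino in place of (benzylamino)methyl on a saturated ring carbon. None of the recorded steps covers this change: the step from compound 1 to compound 2 alters the group on the amine nitrogen, whereas here the amine moves onto the saturated ring carbon itself and its substituents are exchanged. Going by the values given here, the only guide is that compound 3, which also carries its amine directly on that ring carbon, shows the lowest number of the set. Compound 4 is therefore expected to give a somewhat lower number than compound 2, a 1.9-fold lower number from compound 2 to compound 4 (0.27 log units; within the scatter), with an estimate of 3 nM in this assay, within a range from 1 nM to 10 nM.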

Compound 4, half-maximal effective concentration: 3.5 nM
The estimate for compound 4 lay 1.2-fold (0.07 log units) below the measured number, within the range that was stated.
By their numbers in this assay, from the lowest: compound 3; then compounds 4 and 2 (each within the scatter of the next); then compound 1.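

In this assay, for the compounds shown here, the saturated ring carbon three ring bonds from the ring nitrogen accepts a wholesale exchange of its substituent, with a 1.6-fold lower number from compound 2 to compound 4 (0.20 log units; within the scatter): the five-membered aromatic ring with 1 hetero atom stands in for the six-membered aromatic ring of carbon only, and the hydrogen-bond donor of the leaving group has no counterpart in the entering group, yet compound 2 and compound 4 cannot be told apart in this read-out. The replacement of ((phenylsulfonyl)amino)methyl at the same place does register, with a 3.4-fold lower number from compound 1 to compound 4 (0.54 log units; beyond the scatter), so that group remains apart from methyl((thiophen-2-yl)methyl)amino. No measurement is available that would explain either result.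

The exchange alters several features at once, so the compounds shown leave open what the thiophene ring, the methyl on the amine nitrogen and the attachment of that nitrogen directly to the ring carbon each contribute. From the compounds shown here alone, a benzyl(methyl)amino group or a (thiophen-2-ylmethyl)amino group at this place would separate these parts, and whether a furan-2-ylmethyl group or a carboxylic acid is accepted here also remains open.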